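The source may hold more compounds than are shown below. What is called first, only, known or untested is meant among the compounds shown, and "the series" means these compounds.

Measured so far in a functional assay on the whole organism with Mus musculus as the target; on this read-out higher numbers stand for an effect only at larger amounts of compound and lower numbers for an effect already at smaller amounts:
Compound 1 `Cc1cc(-c2ccccc2)nnc1NCCCCN`: 0.1 mg/kg.
Compound 2 `CCN(CC)CCNc1nnc(-c2ccccc2)cc1C`: a limit only, > 10 mg/kg.

Compound 2 stands at the limit of this assay, that is at the limit of > 10 mg/kg in this assay, at which 1 of the 2 values shown sits, with no effect seen in the range tested. Among the measured compounds shown here, only one measured step exists, an at least 100-fold higher number from compound 1 to compound 2 (2.00 log units; beyond the scatter), and it runs in the opposite direction from the change now considered: it replaced a primary amine by a tertiary one. Compound 3 `Cc1cc(-c2ccccc2)nnc1NC(C)CN` differs from compound 2 by 1-(aminomethyl)ethyl in place of 2-(diethylamino)ethyl on a nitrogen on an aromatic ring. This brings back a primary amine of the kind carried by compound 1, although the 1-(aminomethyl)ethyl group is not the same chain as in compound 1, so a full return to the number of compound 1 is not assured. A large step toward lower numbers in this assay is nevertheless expected. Compound 3 is estimated at 1 mg/kg, with a range from 0.2 mg/kg to 10 mg/kg, meaning an expected step of an at least 10-fold lower number from compound 2 to compound 3 (1.00 log units; beyond the scatter).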

Compound 3, minimum effective dose: 2 mg/kg
Beside the measured number, compound 3's estimate is 2.0-fold (0.30 log units) below it; the range from low to high includes it.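

In this assay, a primary amine on a nitrogen on an aromatic ring does not depend on the 4-aminobutyl chain for a measurable effect: the 1-(aminomethyl)ethyl group gives an at least 5.0-fold lower number from compound 2 to compound 3 (0.69 log units; beyond the scatter) on the same core. Compound 2 carries a limit, not a number: the limit of > 10 mg/kg in this assay, at which 1 of the 3 values shown sits.

The chain carrying the primary amine still matters, with 1-(aminomethyl)ethyl in place of 4-aminobutyl giving a 20-fold higher number from compound 1 to compound 3 (1.30 log units; beyond the scatter) in this series.

That change alters chain length and branching together, and the compounds shown do not separate the two; a straight 3-aminopropyl chain would bear on this. Also open, on these data alone, is whether the loss seen with 2-(diethylamino)ethyl follows from the end amine or from the shorter chain, which a 4-(diethylamino)butyl group would address.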